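The source may report more compounds than this note shows. Statements on the series, on what has been measured and on what is new or still open speak of the compounds shown alone.

In an ADME assay on AGS cells (Homo sapiens) for cytotoxicity, read by neutral red uptake, with a stated time of 24 h (a lower number here means a stronger inhibitor, a higher number a weaker inhibitor), compound 1 `CC(C)c1cc2c3c(c1OC(=O)CCl)OC(=O)[C@@]31CCCC(C)(C)[C@@H]1CC2` gives 103000 nM and compound 2 `CC(C)C(=O)Oc1c(C(C)C)cc2c3c1OC(=O)[C@@]31CCCC(C)(C)[C@@H]1CC2` gives 105000 nM, a pair separated by a 1.0-fold higher number from compound 1 to compound 2 (0.01 log units; within the scatter). Compound 3 `CC(C)c1cc2c3c(c1OC(=O)c1cccnc1)OC(=O)[C@@]31CCCC(C)(C)[C@@H]1CC2` gives 280000 nM, the highest of the three numbers. Compound 4 `CC(C)c1cc2c3c(c1OC(=O)CCCc1c[nH]c4ccccc14)OC(=O)[C@@]31CCCC(C)(C)[C@@H]1CC2` replaces the pyridin-3-yl of compound 3 with 3-(1H-indol-3-yl)propyl on a carbonyl carbon: 3-(1H-indol-3-yl)propyl in place of pyridin-3-yl on a carbonyl carbon. Within the data shown here, no measured compound carries this group, so only the steps into compound 3 bear on the change, namely a 2.7-fold higher number from compound 1 to compound 3 (0.43 log units; beyond the scatter) and a 2.7-fold higher number from compound 2 to compound 3 (0.43 log units; beyond the scatter). Both are modest, and they suggest that losing pyridin-3-yl may bring a modest drop. The expected step is a 2.2-fold lower number from compound 3 to compound 4 (0.33 log units; beyond the scatter). For compound 4, the estimated value is 130000 nM, within an expected range of 45000 nM to 350000 nM.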

Compound 4, half-maximal inhibitory concentration: 46800 nM
The estimate for compound 4 lay 2.8-fold (0.44 log units) above the measured number, within the range that was stated.
By their numbers in this assay, from the lowest: compound 4; then compounds 1 and 2 (each within the scatter of the next); then compound 3.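

In this assay, 3-(1H-indol-3-yl)propyl on this carbonyl carbon gives a lower number than either small group, isopropyl (a 2.2-fold lower number from compound 2 to compound 4 (0.35 log units; beyond the scatter)) or chloromethyl (a 2.2-fold lower number from compound 1 to compound 4 (0.34 log units; beyond the scatter)), whereas pyridin-3-yl had given a higher one. Among these compounds, the change from pyridin-3-yl is the largest step seen at this position so far (a 6.0-fold lower number from compound 3 to compound 4 (0.78 log units; beyond the scatter)), so the number here can move in either direction from those two small groups. No evidence at hand accounts for this shift.

The compounds shown leave open whether the 1H-indol-3-yl part or the propyl chain matters more. A 3-phenylpropyl group on the same carbonyl carbon would begin to separate the two.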